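The source may hold more compounds than are shown below. What is called first, only, known or untested is meant among the compounds shown, and "the series" means these compounds.

Of the compounds shown here, three built on one shared core have been measured in a functional assay on A549 cells (Homo sapiens) for inhibition, read by CCK-8 assay, with a stated time of 48 h; a higher number here means a weaker inhibitor, a lower number a stronger inhibitor. Compound 1 `Cc1ccc(NC(=S)NC(=O)c2cn(-c3ccccc3)nc2-c2ccc(Cl)cc2)cc1` gives 2690 nM, compound 2 `COc1ccc(NC(=S)NC(=O)c2cn(-c3ccccc3)nc2-c2ccc(OC)cc2)cc1` gives 750 nM, and compound 3 `O=C(NC(=S)Nc1ccc(Cl)cc1)c1cn(-c2ccccc2)nc1-c1ccc(Cl)cc1` gives 3150 nM. Compound 3 therefore holds the highest of the three numbers. Its nearest neighbour is compound 1, and the step from compound 1 to compound 3 is a 1.2-fold higher number from compound 1 to compound 3 (0.07 log units; within the scatter), a chloro in place of methyl on an aromatic carbon that stays within the scatter. Going by the values given here, compound 2 lies furthest from compound 3 with a clearly lower number, but the two differ at two sites, so no single step connects them.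

Compound 4 `COc1ccc(-c2nn(-c3ccccc3)cc2C(=O)NC(=S)Nc2ccc(Cl)cc2)cc1` is the next structure. Relative to compound 3 it carries methoxy in place of chloro on an aromatic carbon. Among the compounds with values here, the one measured single step, from compound 1 to compound 3, sits at another site and changed nothing beyond the scatter, so it bears only loosely on this change. Compound 2, which carries methoxy at both sites, gives 750 nM. Because compound 2 gives 750 nM, compound 4 is expected to move part of the way toward it, by an estimated 2.1-fold lower number from compound 3 to compound 4 (0.32 log units; beyond the scatter). Compound 4 is accordingly estimated at 1500 nM, with a range from 600 nM to 4000 nM.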

Compound 4, half-maximal inhibitory concentration: 1310 nM
Beside the measured number, compound 4's estimate is 1.1-fold (0.06 log units) above it; the range from low to high includes it.
By their numbers in this assay, from the lowest: compounds 2 and 4 (each within the scatter of the next); then compounds 1 and 3 (each within the scatter of the next).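

In this assay, going by these compounds alone, the change from 4-chlorophenyl to 4-methoxyphenyl gives the first single step beyond the scatter, a 2.4-fold lower number from compound 3 to compound 4 (0.38 log units; beyond the scatter), though it is only modest. At the other substituted aromatic ring, a 1.7-fold higher number from compound 2 to compound 4 (0.24 log units; within the scatter) stays within the scatter, as did a 1.2-fold higher number from compound 1 to compound 3 (0.07 log units; within the scatter), so among these four compounds the two carrying 4-methoxyphenyl, compound 2 and compound 4, hold the two lowest numbers, while the two carrying 4-chlorophenyl, compound 1 and compound 3, hold the two highest. No evidence is available that explains this difference between methoxy and chloro.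

The compounds shown carry only chloro or methoxy at this position, so it remains open how a hydroxyl, an amine or a longer ether chain such as ethoxy would compare there. Also open, as far as these compounds go, is whether the step would keep its size with a trifluoromethyl or a nitrile at the other ring, and whether the order of the compounds extends beyond this assay.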